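Longer and unsaturated side chains on a shared core

The compounds below may be only part of what the source reports. "The series", "measured", "known", "first", "only" and "open" are said of these compounds alone.

Compound 1 `CCCCc1cc2cn(COCCO)c(=O)nc2o1` — in a functional assay on HEL cells (Homo sapiens), read by microscopy (on this read-out higher numbers stand for lower toxicity in this test and lower numbers for higher toxicity in this test), compound 1 gives > 400000 nM, a limit of the assay and not a number.
Compound 2 `CCCCCCCc1cc2cn(COCCO)c(=O)nc2o1` — compound 2 gives 400000 nM.
Compound 3 `CCCCCc1cc2cn(COCCO)c(=O)nc2o1` — compound 3 gives > 400000 nM, again a limit of the assay.

Compound 3 therefore stands at the limit, and no number separates it from the others. Compound 4 is `CCCCCC#Cc1cc2cn(COCCO)c(=O)nc2o1`; the change from compound 3 is hept-1-yn-1-yl in place of pentyl on an aromatic carbon. The measured chain changes bear on it: a number no higher from compound 1 to compound 2 (the limit leaves the size open), a step that the two limits leave unreadable from compound 1 to compound 3 and a number no lower from compound 2 to compound 3 (the limit leaves the size open). None of them is readable in size, since the limit of > 400000 nM in this assay, at which 2 of the 3 values shown sit, caps what can be seen. No step beyond the scatter is expected, and compound 4 is expected to give about 400000 nM, between 150000 nM and 400000 nM. The expected step is a number no higher from compound 3 to compound 4 (the limit leaves the size open).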

Compound 4, minimum cytotoxic concentration: >= 100000 nM
Compound 4 was reported as a limit; the forecaster's own chance of this, stated with the estimate: 65%; the middle value is on the limit's open side.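

No step can be read in size between compound 4 and compound 1, compound 2 or compound 3. The compounds shown leave open whether hept-1-yn-1-yl gives higher or lower toxicity than pentyl or heptyl in this assay.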